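This account rests on a few compounds, and the source may have more. Where it says the series, first, only, none or still open, it means among the compounds named here.

Measured so far in an assay on HEK293 cells for inhibition of sodium- and chloride-dependent glycine transporter 1 (Homo sapiens), read by scintillation proximity assay; on this read-out higher numbers stand for weaker inhibition and lower numbers for stronger inhibition:
compound 1 `O=C(CN(C(=O)c1ccc(-c2ccccn2)cc1)C1CCCCC1)Nc1cc(F)cc(F)c1` — 63.1 nM
compound 2 `O=C(CN(C(=O)c1ccc(-c2ccccn2)cc1)C1CCCOC1)Nc1cc(F)cc(F)c1` — 79.4 nM

Among the compounds with values here, compound 2 stands at one end of these two numbers, but its only neighbour, compound 1, lies within the scatter of it: the step of a 1.3-fold higher number from compound 1 to compound 2 (0.10 log units; within the scatter) does not separate the two. That step, a change of the ring on the amide-type nitrogen, is the only one measured so far at that position.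

Compound 3 `O=C(CN(C(=O)c1ccc(-c2ccccn2)cc1)C1CCOCC1)Nc1cc(F)cc(F)c1` keeps the shared core of compound 2 and differs from it only in oxan-4-yl in place of oxan-3-yl on an amide-type nitrogen. Within the data shown here, the one step that bears on this change is a 1.3-fold higher number from compound 1 to compound 2 (0.10 log units; within the scatter), which stayed within the scatter although it exchanged the whole ring at the same nitrogen; moving the oxygen within the same ring is a smaller change, so no step beyond the scatter is expected in this assay, and the estimated step is a 1.0-fold higher number from compound 2 to compound 3 (0.00 log units; within the scatter). Compound 3 is therefore expected near 80 nM, with a range from 40 nM to 160 nM.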

Compound 3, half-maximal inhibitory concentration in the sodium- and chloride-dependent glycine transporter 1 assay: 1000 nM
Beside the measured number, compound 3's estimate is 13-fold (1.10 log units) below it; the measured number lies above the stated range.
By their numbers in the sodium- and chloride-dependent glycine transporter 1 assay, from the lowest: compounds 1 and 2 (each within the scatter of the next); then compound 3.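

In the sodium- and chloride-dependent glycine transporter 1 assay the group on the amide-type nitrogen proves sensitive to how its ring is joined: compound 2 gives 79.4 nM and compound 3 gives 1000 nM, so oxan-4-yl in place of oxan-3-yl gives a 13-fold higher number from compound 2 to compound 3 (1.10 log units; beyond the scatter), although the two groups have the same atoms. A ring oxygen as such does not set the number, since oxan-3-yl stayed within the scatter of cyclohexyl, whereas oxan-4-yl stands well apart from it, with a 16-fold higher number from compound 1 to compound 3 (1.20 log units; beyond the scatter). In a physicochemical assay for solubility, read by chemiluminescence (on this read-out higher numbers stand for higher solubility and lower numbers for lower solubility), compound 2 gives 56 ug/mL and compound 3 gives 99 ug/mL; the same change gives a 1.8-fold higher number from compound 2 to compound 3 (0.25 log units; within the scatter), and nothing on hand accounts for the large gap between the two oxan groups.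

As far as these compounds go, it remains open whether this step is specific to oxan-4-yl or also comes with a piperidin-4-yl ring, an amine, on the same amide-type nitrogen. From the compounds shown here alone, whether the step carries over to any core other than the shared one also remains open.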